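The source may report more compounds than this note shows. Statements on the series, on what has been measured and on what is new or still open speak of the compounds shown alone.

Measured in an assay on isolated protein for inhibition of protein deacetylase HDAC6 (Homo sapiens), read by fluorescence, with stated times of 15 min and 30 min; on this read-out lower numbers stand for stronger inhibition and higher numbers for weaker inhibition:
Compound 1, `O=C(CCCCCCn1[se]c2ccccc2c1=O)NO`, gives 19 nM.
Compound 2, `O=C(NO)c1ccc(Cn2[se]c3ccccc3c2=O)cc1`, gives 37 nM.
Compound 3, `O=C(CCCCCOc1ccc(-n2[se]c3ccccc3c2=O)cc1)NO`, gives 508 nM.

Of the three numbers in this assay, compound 2 has the second highest. Its number is close to that of compound 1, the two lying within the usual scatter of repeated measurements, so nothing can be said about which of them inhibits more strongly. Compound 3, on the other hand, shows a number clearly higher than compound 2, a gap well beyond the scatter, so compound 2 stands as the stronger inhibitor of that pair.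

Compound 4, `O=C(NO)c1ccc(Cn2[se]c3ccc(C(F)(F)F)cc3c2=O)cc1`, keeps the whole of compound 2 and alters one spot on the shared core: trifluoromethyl in place of hydrogen on an aromatic carbon. The hydroxamic acid, the connecting benzyl group and the rest of the core are unchanged.

Within the data shown here, no pair of measured compounds differs in only this one place, so there is no measured step to lean on. With the part that carries the hydroxamic acid left untouched, a change of this kind is expected to move the number little, in no clear direction, and not beyond the scatter. Compound 4 is therefore expected to give 40 nM, with a range from 15 nM to 120 nM. The expected step is a 1.1-fold higher number from compound 2 to compound 4 (0.03 log units; within the scatter).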

Compound 4, half-maximal inhibitory concentration: 584 nM
The estimate for compound 4 lay 15-fold (1.16 log units) below the measured number; measured number above the stated range.
By their numbers in this assay, from the lowest: compounds 1 and 2 (each within the scatter of the next); then compounds 3 and 4 (each within the scatter of the next).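

In this assay, this aromatic carbon of the shared core proves far from indifferent: trifluoromethyl in place of hydrogen gives a 16-fold higher number from compound 2 to compound 4 (1.20 log units; beyond the scatter), a large loss of inhibition even though the hydroxamic acid and the connecting benzyl group stay exactly as they were. The earlier compounds shown here differ from one another in more than one place, so they could not show that a single change on the core, away from the hydroxamic acid, can on its own weaken inhibition this much. Nothing available here says why this one substitution has so large an effect.

On these data alone, it remains open whether any group on this carbon weakens inhibition or whether the result is specific to trifluoromethyl; a fluorine atom, a methyl group or a methoxy group at the same place on compound 2 would help separate those two readings. Also open, as far as these compounds go, is whether trifluoromethyl at this carbon would have a similar effect on compound 1, in which a chain rather than the benzyl group carries the hydroxamic acid.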